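The compounds below may be only part of what the source reports. "The series", "measured", "known", "first", "only" and "open" are said of these compounds alone.

Compound 2, `COc1ccccc1-c1ccc(-c2nnc(N(C)Cc3ccc4nccn4c3)o2)cc1`, gives 4.1 in a physicochemical assay for lipophilicity, at pH 7.4 (on this read-out higher numbers stand for higher lipophilicity and lower numbers for lower lipophilicity), the lower of the two numbers recorded so far. Its nearest neighbour is compound 1, `CN(Cc1ccc2nccn2c1)c1nnc(-c2ccc(-c3ccccc3F)cc2)o1`, which in this assay gives 4.4; the step of a number 0.30 log units lower from compound 1 to compound 2 (within the scatter) lies within the scatter, so the two compounds are not told apart on this read-out.

Compound 3, `CN(Cc1ccc2nccn2c1)c1nnc(-c2ccc(-c3ccccc3C#N)cc2)o1`, arises from compound 2 by one change: cyano in place of methoxy on an aromatic carbon. For the measured compounds named here, no measured step sets cyano against methoxy; the only step known, a number 0.30 log units lower from compound 1 to compound 2 (within the scatter), sets fluoro against methoxy and bears on this case only at a distance, and it was too small to reach beyond the scatter. The expectation for compound 3 is therefore drawn without a direct precedent: a step of a number 0.50 log units lower from compound 2 to compound 3 (beyond the scatter) is estimated, a modest move downward. Compound 3 is thus expected to come in at 3.6, with a range from 3.1 to 4.1.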

Compound 3, distribution coefficient: 3.6
Estimate against measurement, compound 3: no gap at the digits printed; the measured number falls inside the stated range.
By their numbers in this assay, from the lowest: compound 3; then compounds 2 and 1 (each within the scatter of the next).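

For the compounds shown here, at this position, on an aromatic carbon ortho to a large group, cyano gives the first change that clears the scatter in this assay: a number 0.50 log units lower from compound 2 to compound 3 (beyond the scatter) and a number 0.80 log units lower from compound 1 to compound 3 (beyond the scatter). Compound 1 and compound 2 could not be told apart, whereas cyano shows that the read-out can move here, even though methoxy and cyano have the same count of heavy atoms and of hydrogen-bond acceptors. Nothing at hand explains why this change shifts the number.

Only three groups at this one position are shown, so these compounds cannot say whether the shift is particular to cyano. As far as these compounds go, how an amine or a carboxylic acid in this place would read in this assay remains open, as does whether the same change elsewhere on the shared core would give a similar step.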